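Working notes: amino in place of methylsulfanyl, compound 1 to 4

This account rests on a few compounds, and the source may have more. Where it says the series, first, only, none or still open, it means among the compounds named here.

Measured compounds:
compound 1 `CSc1nc(SC)c2ncn([C@@H]3C[C@@H](O)[C@H](CO)O3)c2n1`: > 300 uM
compound 2 `CN(C)c1nc(Br)nc2c1ncn2[C@@H]1C[C@@H](O)[C@H](CO)O1`: 164 uM
compound 3 `CNc1nc(Br)nc2c1ncn2[C@@H]1C[C@@H](O)[C@H](CO)O1`: 140 uM

In a functional assay on U-937 cells (Homo sapiens) (on this read-out higher numbers stand for weaker inhibition and lower numbers for stronger inhibition), compound 1 gives only a limit, > 300 uM; this is the limit of > 300 uM in this assay, at which 1 of the 3 values shown sits. Among the measured compounds shown here, the two numbers in this assay come from compound 2 and compound 3, and the step of a 1.2-fold lower number from compound 2 to compound 3 (0.07 log units; within the scatter) is the only measured step in the set. Compound 4 `CSc1nc(N)c2ncn([C@@H]3C[C@@H](O)[C@H](CO)O3)c2n1` differs from compound 1 by amino in place of methylsulfanyl on an aromatic carbon. The measured step concerns a different change at a different place, so it gives no direct measure of what amino in place of methylsulfanyl does. Compound 2 and compound 3, which carry an amine-type group at the place where compound 4 carries amino, both give numbers below the limit of compound 1. Compound 4 is therefore expected to give a number rather than a limit, with the step of an at least 1.6-fold lower number from compound 1 to compound 4 (0.22 log units; that floor lies within the scatter) expected toward stronger inhibition, though with wide uncertainty. The estimate for compound 4 in this assay is 180 uM, within 50 uM to 600 uM.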

Compound 4, concentration for 50% inhibition: > 300 uM
Compound 4 gave a limit, no number (the forecaster's own chance of this, stated with the estimate: 40%); middle value at least 1.6-fold (0.22 log units) from the limit.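

In this assay, among the compounds shown here, compound 1 and compound 4 both give only a limit and no number, so no step between them can be read: the limit of > 300 uM in this assay, at which 2 of the 4 values shown sit. The compounds shown leave open both the size and the direction of what amino in place of methylsulfanyl does to the read-out.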